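The source may report more compounds than this note shows. Statements on the series, on what has been measured and on what is new or still open speak of the compounds shown alone.

Compound 1 `COc1cccc(/C=C/C(=O)c2ccc(OC)c3c2OC(C)(C)C=C3)c1` in a functional assay on HepG2 cells (Homo sapiens) for antiproliferative activity, read by MTT assay, with a stated time of 24 h (a higher number here means a weaker inhibitor, a lower number a stronger inhibitor), gives only a limit, > 10000 nM. Going by the values given here, compound 2 `COc1ccc(C(=O)/C=C/c2ccccn2)c2c1C=CC(C)(C)O2` gives 5760 nM in this assay, the only number so far. The step of an at least 1.7-fold lower number from compound 1 to compound 2 (0.23 log units; that floor lies within the scatter) is thus bounded from below only, its floor set by the limit of > 10000 nM in this assay, at which 1 of the 2 values shown sits. Compound 3 `COc1ccc(C(=O)/C=C/c2ccc(Cl)c(Cl)c2)c2c1C=CC(C)(C)O2` carries 3,4-dichlorophenyl in place of pyridin-2-yl on a double-bonded chain carbon bound to a double-bonded chain carbon. Among the compounds with values here, no measured step covers an aryl swap of this kind; the single step of an at least 1.7-fold lower number from compound 1 to compound 2 (0.23 log units; that floor lies within the scatter) is the nearest and is modest. The expected step of a 1.2-fold lower number from compound 2 to compound 3 (0.06 log units; within the scatter) in this assay is therefore modest, without a firm direction. Compound 3 is estimated at 5000 nM, within 1500 nM to 15000 nM.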

Compound 3, half-maximal inhibitory concentration: > 10000 nM
Compound 3 ended at the assay's limit; the forecaster's own chance of this, stated with the estimate: 25%; middle value at least 2.0-fold (0.30 log units) away from the limit.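

At this place, on a double-bonded chain carbon bound to a double-bonded chain carbon, 3,4-dichlorophenyl in place of pyridin-2-yl gives an at least 1.7-fold higher number from compound 2 to compound 3 (0.23 log units; that floor lies within the scatter), a step bounded from one side only. Among the groups shown, only pyridin-2-yl gives a number in this assay, while the step between compound 1 and compound 3 cannot be read. Reading of this place is held back by the assay's limit: the limit of > 10000 nM in this assay, at which 2 of the 3 values shown sit.

On these data alone, whether the ring nitrogen of pyridin-2-yl or the two chlorines set the difference stays open. An unsubstituted phenyl ring or an amine-bearing phenyl ring at this place would help separate the two.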